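A few compounds are considered here, and "the series" means these few. Any claim that something is new, unique, unknown or untested is made for them only; others in the source may bear on it.

Measured so far:
compound 1 `COc1cccc2c1CCC2c1ncc[nH]1` — 65%
compound 2 `Cc1oncc1-c1cccc2c1CCC2c1ncc[nH]1` — 63%

In a functional assay on CHO cells for agonist activity at Alpha-1A adrenergic receptor (Homo sapiens), read by FLIPR and calcium flux (on this read-out lower numbers stand for smaller maximal responses and higher numbers for larger maximal responses), compound 2 stands lowest of the two numbers, with compound 1 nearest; the step of a number 2 percentage points lower from compound 1 to compound 2 (within the scatter) is within the scatter. Compound 3 `c1cc(-c2ncco2)c2c(c1)C(c1ncc[nH]1)CC2` differs from compound 2 by 1,3-oxazol-2-yl in place of 5-methyl-1,2-oxazol-4-yl on an aromatic carbon. For the measured compounds named here, the only measured step that bears on this, a number 2 percentage points lower from compound 1 to compound 2 (within the scatter), exchanged a group at this same place and left the largest response essentially unchanged. The step of a number 3 percentage points lower from compound 2 to compound 3 (within the scatter) is therefore expected to stay within the scatter. Compound 3 is estimated at 60%, in the range 45% to 75%.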

Compound 3, largest response reached (Emax), in percent of the reference or control that the assay uses: 63%
For compound 3 the middle estimate is 3 percentage points below the measured one; measured number inside the range.
By their numbers in this assay, from the lowest: compounds 2, 3 and 1 (each within the scatter of the next).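

In this assay the exchange of one ring for another gives no change at the digits printed from compound 2 to compound 3 (within the scatter), and the comparison with the methoxy compound gives a number 2 percentage points lower from compound 1 to compound 3 (within the scatter). On this aromatic carbon, then, methoxy, 5-methyl-1,2-oxazol-4-yl and 1,3-oxazol-2-yl all give the same largest response within the scatter, even though the two rings differ in their hetero atom arrangement and point of attachment. Nothing available explains this steadiness. Still open, on these data alone, is whether an amine or a carboxylic acid on this carbon would leave the response equally unchanged.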